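Benzyl in Place of 2-Chlorophenyl on an Amide Nitrogen

The source may hold more compounds than are shown below. What is called first, only, known or untested is meant among the compounds shown, and "the series" means these compounds.

Measured so far:
Compound 1 `CC(CSc1nnc(-c2ccncc2)s1)C(=O)NCc1ccccc1`: in an ADME assay on HepG2 cells (Homo sapiens) for cytotoxicity, with a stated time of 3 days (on this read-out higher numbers stand for lower toxicity in this test and lower numbers for higher toxicity in this test), compound 1 gives > 50000 nM, which is a limit of the assay and not a number.
Compound 2 `O=C(CSc1nnc(-c2ccncc2)s1)Nc1ccccc1Cl`: in this assay compound 2 gives > 50000 nM, again a limit of the assay.
Compound 3 `CC(CSc1nnc(-c2ccncc2)s1)C(=O)Nc1ccccc1Cl`: in this assay compound 3 gives > 50000 nM, also a limit of the assay.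

All three measured compounds therefore sit at the same boundary of the test, as the evidence shows (the limit of > 50000 nM in this assay, at which 3 of the 3 values shown sit). Going by the values given here, the one structural change that has been made between measured compounds is benzyl in place of 2-chlorophenyl on an amide-type nitrogen. Because both ends of that pair are limits, the step that the two limits leave unreadable from compound 3 to compound 1 cannot be read off; its size is simply not known from these data.

Compound 4 `O=C(CSc1nnc(-c2ccncc2)s1)NCc1ccccc1` has not yet been measured in this assay. It is related to compound 2 by the same change, (benzyl in place of 2-chlorophenyl on an amide-type nitrogen), made at a place described in exactly the same words as for the pair of compound 3 and compound 1. How the core of compound 2 differs from the core of compound 3 is not broken down here.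

Among the compounds with values here, with nothing to go on but the unreadable step from compound 3 to compound 1 a step that the two limits leave unreadable from compound 3 to compound 1 and the fact that every value so far sits at the limit (the limit of > 50000 nM in this assay, at which 3 of the 3 values shown sit), the step from compound 2 to compound 4 is expected to be small, about a step that the limit leaves unreadable from compound 2 to compound 4, with a real chance that the assay again reports only a limit. On that basis compound 4 is estimated at 80000 nM, within a range from 30000 nM to 300000 nM.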

Compound 4, half-maximal cytotoxic concentration: 17700 nM
Compound 4: middle estimate off by 4.5-fold (0.66 log units), on the high side; the whole stated range lies above it.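

In this assay, putting benzyl in place of 2-chlorophenyl on an amide-type nitrogen gives an at least 2.8-fold lower number from compound 2 to compound 4 (0.45 log units; beyond the scatter), so on the core of compound 2 this change goes with a lower number, which on this read-out means higher toxicity in this test. The same change on the core of compound 3 cannot be read, because both ends of that pair sit at the boundary of the test: the limit of > 50000 nM in this assay, at which 3 of the 4 values shown sit. The change is therefore seen to matter on one core only; these results neither confirm nor rule out a similar step on the second core, and the step that can be read gives only a smallest size, with its upper end left open.

The chlorine leaves and the benzyl enters in a single change, so the compounds shown leave open which part of that swap goes with the lower number, a question that plain phenyl or 2-chlorobenzyl on the same nitrogen could help to separate. They also leave open how the number would respond to other groups at this place, such as a 2-phenylethyl chain or a cyclohexyl ring, on either core.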